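Cytotoxicity series on colon epithelial cells: all values at limit

The source may hold more compounds than are shown below. What is called first, only, known or untested is meant among the compounds shown, and "the series" means these compounds.

Measured compounds:
compound 1 `CCOc1ccc(NC(=O)c2cccc(/C=C3\CC(=O)N(Cc4ccccc4)C3=O)c2)cc1`; in an ADME assay on NCM460 cells (Homo sapiens) for cytotoxicity, read by MTT assay, with a stated time of 72 h (on this read-out lower numbers stand for stronger inhibition and higher numbers for weaker inhibition), compound 1 gives > 100000 nM, a limit of the assay.
compound 2 `CCOc1ccc(NC(=O)c2cccc(/C=C3\CC(=O)N(c4ccccc4)C3=O)c2)cc1`; in this assay compound 2 gives > 100000 nM, again a limit.
compound 3 `CCCCCN1C(=O)C/C(=C\c2cccc(C(=O)NCCCC)c2)C1=O`; in this assay compound 3 gives > 100000 nM, also a limit.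

Compound 2 thus stands at a limit of this assay and nowhere on a numbered scale; every other value shown is a limit as well, see (the limit of > 100000 nM in this assay, at which 3 of the 3 values shown sit). Within the data shown here, the one step between compounds that differ in a single place, a step that the two limits leave unreadable from compound 1 to compound 2, cannot be read for size or direction, so no measured step bears usefully on the change now considered.

Compound 4 `CSc1cccc(NC(=O)c2cccc(/C=C3\CC(=O)N(c4ccccc4)C3=O)c2)c1` differs from compound 2 as follows: 3-(methylsulfanyl)phenyl in place of 4-ethoxyphenyl on an amide-type nitrogen. With the measured steps unreadable and all three values sitting at the limit, no step beyond the scatter is expected in this assay in either direction. Compound 4 is therefore estimated at 200000 nM, within a range from 60000 nM to 700000 nM. The step expected from compound 2 to compound 4 is a step that the limit leaves unreadable from compound 2 to compound 4, and the most likely outcome is that compound 4 is reported only as a limit.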

Compound 4, half-maximal inhibitory concentration: > 100000 nM
Compound 4 was reported as a limit; the forecaster's own chance of this, stated with the estimate: 80%; the middle value is on the limit's open side.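

Compound 2 and compound 4 both sit at a limit of this assay, so no new step can be read between them, in size or in direction: the limit of > 100000 nM in this assay, at which 4 of the 4 values shown sit.

Going by these compounds, whether any change to the shared core gives a numbered value in this assay stays open.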